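This account rests on a few compounds, and the source may have more. Where it says the series, first, only, none or still open, it means among the compounds named here.

Compound 1 `COc1ccc(Cl)cc1N(CC(=O)Nc1ccccc1)S(=O)(=O)c1ccccc1` gives in a functional assay on SH-SY5Y cells (Homo sapiens), read by MTT assay, with a stated time of 24 h (on this read-out lower numbers stand for an effect already at smaller amounts and higher numbers for an effect only at larger amounts of compound), the result > 20000 nM, which is a limit of the assay and not a number.
Compound 2 `COc1ccccc1NC(=O)CN(c1cc(Cl)ccc1OC)S(=O)(=O)c1ccccc1` gives in this assay the value 15500 nM.

Within the data shown here, compound 2 therefore holds the only number obtained here; the other result is a limit. Among the measured compounds shown here, the step of an at least 1.2-fold lower number from compound 1 to compound 2 (0.11 log units; that floor lies within the scatter) is the only measured comparison, and it rests on the limit described by the limit of > 20000 nM in this assay, at which 1 of the 2 values shown sits, so its floor is too small to count as a real change.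

Compound 3 `COc1ccc(Cl)cc1N(CC(=O)Nc1ccc([N+](=O)[O-])cc1)S(=O)(=O)c1ccccc1` differs from compound 2 by 4-nitrophenyl in place of 2-methoxyphenyl on an amide-type nitrogen. This is a different kind of change from the one measured: there a methoxy was added, here one substituted phenyl ring is exchanged for another. For the measured compounds named here, no measured step covers that exchange, so the only guidance is that the one change tried on this part of the molecule did not move the number beyond the scatter.

The expected outcome is that compound 3 shows a step of a 1.2-fold higher number from compound 2 to compound 3 (0.06 log units; within the scatter), that is, no clear change. Compound 3 is accordingly estimated at 18000 nM, with a range from 6000 nM to 60000 nM.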

Compound 3, half-maximal effective concentration: 8210 nM
The estimate for compound 3 lay 2.2-fold (0.34 log units) above the measured number; measured number inside the range.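

Among these compounds, on the phenyl ring carried by the amide-type nitrogen, a nitro group in place of hydrogen gives the first step beyond the scatter in this assay (an at least 2.4-fold lower number from compound 1 to compound 3 (0.38 log units; beyond the scatter)), which shows that a change at this position can move the number measurably. Going by these compounds, that figure is only a floor, and the true size of the step stays unknown, since the result for compound 1 is a limit of the assay and not a number: the limit of > 20000 nM in this assay, at which 1 of the 3 values shown sits. The exchange of 2-methoxyphenyl for 4-nitrophenyl, by contrast, stays within the scatter (a 1.9-fold lower number from compound 2 to compound 3 (0.28 log units; within the scatter)), so these two substituted rings cannot be ranked on the present numbers, even though they differ in both the group and its printed ring number.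

The compounds shown leave open whether the clear step belongs to the nitro group itself or would also appear with other groups on this ring, and whether 2-nitrophenyl or 4-methoxyphenyl would read differently from the two rings compared here. Also open, on these data alone, is how an amine or a carboxylic acid on this ring would read.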